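The compounds below may be only part of what the source reports. "The series", "measured", "known", "first", "only" and "open" are said of these compounds alone.

Working notes on the series. In a functional assay on HCT-116 cells (Homo sapiens) for cytotoxicity, read by sulforhodamine B assay (on this read-out lower numbers stand for an effect already at smaller amounts and higher numbers for an effect only at larger amounts of compound), compound 1 `CCCCCCCCCCCCCCCCCCCCCCCCc1cn([C@@H](CO)[C@H](O)[C@H](O)CCCCCCCCCCCCCC)nn1` gives > 50000 nM, a limit and not a number. Compound 2 `CCCCCCCCCCCCCC[C@@H](O)[C@@H](O)[C@H](CO)n1cc(CCC)nn1` gives 13900 nM. Within the data shown here, compound 3 `CCCCCCCCCCCCCC[C@@H](O)[C@@H](O)[C@H](CO)n1cc(CCCC)nn1` gives 12900 nM, which places it within the scatter of compound 2, and these two are the only numbers available.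

Next is compound 4 `CCCCCCCCCCCCCC[C@@H](O)[C@@H](O)[C@H](CO)n1cc(CCCCCC)nn1`, reached from compound 3 by ethyl in place of hydrogen on a saturated chain carbon, four bonds along the chain from an aromatic carbon. Among the measured compounds shown here, the one measured step of this kind, a 1.1-fold lower number from compound 2 to compound 3 (0.03 log units; within the scatter), is a smaller extension of the same chain and stays within the scatter. No step beyond the scatter is therefore expected in this assay. With a far longer chain on the shared core, compound 1 stands at the limit of > 50000 nM in this assay, at which 1 of the 3 values shown sits, so the upper end of the range is kept wide. The estimated step is a 1.1-fold lower number from compound 3 to compound 4 (0.03 log units; within the scatter), expected to remain within the scatter. For compound 4 the expected value is 12000 nM, with an estimated range of 6000 nM to 26000 nM.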

Compound 4, half-maximal effective concentration: 12000 nM
For compound 4 middle estimate and measured number coincide at the digits printed; the measured number falls inside the stated range.
By their numbers in this assay, from the lowest: compounds 4, 3 and 2 (each within the scatter of the next). At a limit, above all of these: compound 1.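

In this assay, the larger extension at this position, ethyl in place of hydrogen on a saturated chain carbon, four bonds along the chain from an aromatic carbon, still gives only a 1.1-fold lower number from compound 3 to compound 4 (0.03 log units; within the scatter). The widest change among the measured numbers gives a 1.2-fold lower number from compound 2 to compound 4 (0.06 log units; within the scatter). Among these compounds, compound 2, compound 3 and compound 4 therefore cannot be told apart in this assay, so the flat reading now holds over a wider span of chain than the single earlier step covered.

Compound 1, with its far longer chain on the shared core, remains a limit and not a number: the limit of > 50000 nM in this assay, at which 1 of the 4 values shown sits. Open, on these data alone, is how a chain such as decyl would read between compound 4 and compound 1, and whether a chain ending in an amine or a carboxylic acid would depart from this flat reading.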